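This account rests on a few compounds, and the source may have more. Where it says the series, first, only, none or still open, it means among the compounds named here.

Of the compounds shown here, two with a shared core have been measured in a functional assay on L1210 cells (Mus musculus) for antiproliferative activity; a higher number here means that more compound is needed for the effect, a lower number that less compound is needed. Compound 1 `CCCCCCCO/N=C/c1cc(OC)c2c(c1OC)C(=O)C=CC2=O` gives 0.213 ug/mL in this assay, and compound 2 `CCCCCO/N=C/c1cc(OC)c2c(c1OC)C(=O)C=CC2=O` gives 0.175 ug/mL. Compound 2 carries the lower of these two numbers, but the step from compound 1 to compound 2 is a 1.2-fold lower number from compound 1 to compound 2 (0.09 log units; within the scatter), so the two lie within the scatter of each other. That step is a shortening of the chain on the oxygen: hydrogen in place of ethyl on a saturated chain carbon, five bonds along the chain from an oxygen on an unsaturated carbon.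

Compound 3 `CCCCCCCCCCCCO/N=C/c1cc(OC)c2c(c1OC)C(=O)C=CC2=O` extends that same chain in the other direction: heptyl in place of hydrogen on a saturated chain carbon, five bonds along the chain from an oxygen on an unsaturated carbon. Among the measured compounds shown here, the only measured step that bears on this change is the one from compound 1 to compound 2, and it stayed within the scatter. On that basis no step beyond the scatter is expected from compound 2 to compound 3, so the expected change is a 1.4-fold higher number from compound 2 to compound 3 (0.15 log units; within the scatter). Compound 3 is therefore estimated at 0.25 ug/mL in this assay, with a range from 0.08 ug/mL to 0.8 ug/mL.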

Compound 3, concentration for half-maximal effect: 0.311 ug/mL
The estimate for compound 3 lay 1.2-fold (0.09 log units) below the measured number; the measured number falls inside the stated range.
By their numbers in this assay, from the lowest: compounds 2, 1 and 3 (each within the scatter of the next).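

At this saturated chain carbon, five bonds along the chain from an oxygen on an unsaturated carbon, heptyl in place of hydrogen gives a 1.8-fold higher number from compound 2 to compound 3 (0.25 log units; within the scatter) in this assay, so a much larger addition than the ethyl of the earlier step still does not leave the scatter. Pentyl in place of hydrogen, seven bonds along the chain from that oxygen, gives a 1.5-fold higher number from compound 1 to compound 3 (0.16 log units; within the scatter) as well, and so compounds 1, 2 and 3 do not separate from one another in this assay across the chains shown. No measured evidence is available to explain this flat result. 

As far as these compounds go, it remains open whether a longer chain than that of compound 3 would produce a step beyond the scatter. From the compounds shown here alone, it is equally open whether an amine or a carboxylic acid at the end of the chain would do so.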